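Cyano in place of isopropoxy: estimating cell toxicity

The source may hold more compounds than are shown below. What is called first, only, known or untested is meant among the compounds shown, and "the series" means these compounds.

Of the compounds shown here, three sharing one core have been measured in an ADME assay on L6 cells (Rattus norvegicus) for cytotoxicity, read by resazurin assay, with a stated time of 72 h; a lower number here means a stronger inhibitor, a higher number a weaker inhibitor. Compound 1 `OC(c1ccc(Cl)cc1)(c1cccnc1)c1ccccc1F` is reported as > 100000 nM, which is a limit of the assay and not a number. Compound 2 `COc1ccc(C(O)(c2ccc(Cl)cc2)c2cccnc2)cc1` gives 68100 nM, and compound 3 `CC(C)Oc1cccc(C(O)(c2ccc(Cl)cc2)c2cccnc2)c1` gives 67600 nM. These two values lie within the usual scatter of repeated measurements, so compound 3 stands level with compound 2 and no order can be read between them.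

The next compound is compound 4 `N#Cc1cccc(C(O)(c2ccc(Cl)cc2)c2cccnc2)c1`, which carries cyano in place of isopropoxy on an aromatic carbon, meta to a large group: cyano in place of isopropoxy on an aromatic carbon. Within the data shown here, no two measured compounds differ in just one place, so no direct step serves as a guide. Among the measured compounds shown here, the only guide is the general level of the set: despite their different structures, compound 2 sits at 68100 nM and compound 3 sits at 67600 nM. In this assay, no change beyond the scatter is therefore expected, with perhaps a slight drift towards a higher number. The expected move is small, a 1.2-fold higher number from compound 3 to compound 4 (0.07 log units; within the scatter). Compound 4 is estimated at 80000 nM, with an expected range from 38000 nM to 100000 nM.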

Compound 4, half-maximal inhibitory concentration: > 100000 nM
Compound 4 ended at the assay's limit; the forecaster's own chance of this, stated with the estimate: 35%; middle value at least 1.2-fold (0.09 log units) away from the limit.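

Among these compounds, replacing isopropoxy with cyano on this aromatic carbon gives the set its first comparison in which only one place changes, and in this assay the result is an at least 1.4-fold higher number from compound 3 to compound 4 (0.17 log units; that floor lies within the scatter). Compound 4 reads > 100000 nM, which is a limit of the assay and not a number. This shows that the smaller cyano group, with 2 heavy atoms against the 4 of isopropoxy, brings no sign of a lower number at this position, but the step can be read only as a floor, and its true size stays unknown because of where the value sits: the limit of > 100000 nM in this assay, at which 2 of the 4 values shown sit.

From the compounds shown here alone, whether any group at this position can bring the number down remains open, since the comparison covers only isopropoxy and cyano here, and an amine or a carboxylic acid on the same aromatic carbon would be a useful test. It is also unknown whether the same swap would read the same way if other parts of the shared core were changed.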